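The source may hold more compounds than are shown below. What is called first, only, known or untested is meant among the compounds shown, and "the series" means these compounds.

Three compounds have been measured in a toxicity assay on GES1 cells (Homo sapiens) for inhibition, read by MTT assay, with a stated time of 72 h; on this read-out lower numbers stand for stronger inhibition and higher numbers for weaker inhibition:

Compound 1 `Cc1cc(N2CC[C@@H](C)[C@@H](N(C)c3ncnc4[nH]ccc34)C2)n2nc(SCc3ccccc3Br)nc2n1`: > 100000 nM
Compound 2 `Cc1cc(N2CC[C@@H](C)[C@@H](N(C)c3ncnc4[nH]ccc34)C2)n2nc(SCCc3ccccc3)nc2n1`: 66200 nM
Compound 3 `Cc1cc(N2CC[C@@H](C)[C@@H](N(C)c3ncnc4[nH]ccc34)C2)n2nc(SCC3CCCCC3)nc2n1`: 98200 nM

The entry for compound 1 is a limit of the assay, not a number. Compound 3 gives 98200 nM, within the scatter of compound 2 at 66200 nM.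

Compound 4 `C=CCSc1nc2nc(C)cc(N3CC[C@@H](C)[C@@H](N(C)c4ncnc5[nH]ccc45)C3)n2n1` has vinyl in place of cyclohexyl on a saturated chain carbon bound to a sulfur. Among the measured compounds shown here, three measured steps bear on this change: a 1.5-fold higher number from compound 2 to compound 3 (0.17 log units; within the scatter), an at least 1.5-fold lower number from compound 1 to compound 2 (0.17 log units; that floor lies within the scatter) and an at least 1.0-fold lower number from compound 1 to compound 3 (0.00 log units; that floor lies within the scatter). None goes beyond the scatter, though each group involved holds a ring and vinyl holds none. In this assay, the expected change is therefore no larger than the scatter, with the estimated step being a 1.2-fold lower number from compound 3 to compound 4 (0.09 log units; within the scatter). Compound 4 is expected at 80000 nM, with an estimated range of 35000 nM to 120000 nM.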

Compound 4, half-maximal inhibitory concentration: > 100000 nM
Compound 4 gave a limit, no number; the forecaster's own chance of this, stated with the estimate: 30%; middle value at least 1.2-fold (0.09 log units) away from the limit.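

In this assay compound 4 gives > 100000 nM, which is a limit of the assay and not a number. The readable steps are an at least 1.0-fold higher number from compound 3 to compound 4 (0.00 log units; that floor lies within the scatter) and an at least 1.5-fold higher number from compound 2 to compound 4 (0.17 log units; that floor lies within the scatter), so a group holding no ring, placed on a saturated chain carbon bound to a sulfur, shows no stronger inhibition than the groups holding one. The step between compound 1 and compound 4 cannot be read, and the limit now holds for both: the limit of > 100000 nM in this assay, at which 2 of the 4 values shown sit.

From the compounds shown here alone, whether an amine or a carboxylic acid at this place would give a number beyond the scatter of these values stays open. So do the actual values of compound 1 and compound 4.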